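Aryl variation on the amide chain of the shared core

This account rests on a few compounds, and the source may have more. Where it says the series, first, only, none or still open, it means among the compounds named here.

Compound 3 `O=C(CCc1ccccc1F)Nc1nc2ccccc2c(=O)s1` gives 801 nM in an assay on CHO cells for displacement of a labelled ligand from adenosine receptor A2b (Homo sapiens), read by scintillation counting, with a stated time of 75 min (on this read-out lower numbers stand for stronger inhibition and higher numbers for weaker inhibition), and is the only one of the three measured compounds that returns a number. Compound 1 `CN(C(=O)CCCc1ccccc1)c1nc2ccccc2c(=O)s1` sits at a limit of this assay, > 1000 nM, which is not a number. Compound 2 `O=C(CCCc1ccccc1)Nc1nc2ccccc2c(=O)s1` likewise sits at a limit, > 1000 nM. The step that the two limits leave unreadable from compound 1 to compound 2 stays unreadable because both ends rest at the limit of > 1000 nM in this assay, at which 2 of the 3 values shown sit. Among the measured compounds shown here, the step of an at least 1.2-fold lower number from compound 2 to compound 3 (0.09 log units; that floor lies within the scatter) is the only one touching the aryl group at this position, and its floor lies within the scatter.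

Compound 4 `O=C(CCc1ccc(Cl)c(Cl)c1)Nc1nc2ccccc2c(=O)s1` differs from compound 3 by 3,4-dichlorophenyl in place of 2-fluorophenyl on a saturated chain carbon, two bonds along the chain from a carbonyl carbon. For the measured compounds named here, no measured step exchanges one halogenated phenyl for another, so the only guidance is the step just described, itself inside the scatter. A step of a 1.6-fold lower number from compound 3 to compound 4 (0.20 log units; within the scatter) toward a somewhat lower number is therefore expected, with no confidence that it exceeds the scatter. Compound 4 is estimated at 500 nM, within the range 200 nM to 1500 nM.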

Compound 4, inhibition constant: > 1000 nM
Compound 4 gave a limit, no number; the forecaster's own chance of this, stated with the estimate: 25%; middle value at least 2.0-fold (0.30 log units) from the limit.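

Among the compounds shown here, the change from 2-fluorophenyl to 3,4-dichlorophenyl on a saturated chain carbon, two bonds along the chain from a carbonyl carbon, gives the first direct comparison of two substituted aryl groups at this position in this assay: an at least 1.2-fold higher number from compound 3 to compound 4 (0.09 log units; that floor lies within the scatter). For the compounds shown here, compound 4 rests at a limit of the assay, > 1000 nM, which is not a number, so this comparison does not separate the two aryl groups, and compound 3 remains the only compound with a number. The remaining step, to compound 4 from compound 2, cannot be read because both ends rest at a limit: the limit of > 1000 nM in this assay, at which 3 of the 4 values shown sit.

As far as these compounds go, whether 2-fluorophenyl and 3,4-dichlorophenyl truly differ at this position remains open. Also open, from the compounds shown here alone, is how a methoxyphenyl group or a pyridine ring would read in place of these aryl groups.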